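Triazole aryl swap: dinitrophenyl on the spiro-oxindole core

This account rests on a few compounds, and the source may have more. Where it says the series, first, only, none or still open, it means among the compounds named here.

Three analogues of one shared core have been tested in a functional assay on HepG2 cells (Homo sapiens) for antiproliferative activity, read by MTT assay, with a stated time of 48 h; on this read-out higher numbers stand for weaker inhibition and lower numbers for stronger inhibition. Compound 1 `Cc1ccc(C)c(-n2nncc2CN2C(=O)C3(C(C#N)=C(N)Oc4c(N)cc5nc6ccccc6nc5c43)c3ccccc32)c1` reaches only the limit of the assay, > 50000 nM (the limit of > 50000 nM in this assay, at which 1 of the 3 values shown sits). Compound 2 `COc1ccc(OC)c(-n2nncc2CN2C(=O)C3(C(C#N)=C(N)Oc4c(N)cc5nc6ccccc6nc5c43)c3ccccc32)c1` gives 45100 nM, and compound 3 `Cc1ccc(Cl)cc1-n1nncc1CN1C(=O)C2(C(C#N)=C(N)Oc3c(N)cc4nc5ccccc5nc4c32)c2ccccc21` gives 17300 nM, the lowest of the two numbers. The steps of an at least 1.1-fold lower number from compound 1 to compound 2 (0.04 log units; that floor lies within the scatter) and a 2.6-fold lower number from compound 2 to compound 3 (0.42 log units; beyond the scatter) and an at least 2.8-fold lower number from compound 1 to compound 3 (0.46 log units; beyond the scatter) all involve changes of the aryl group on the triazole nitrogen. Compound 4 `N#CC1=C(N)Oc2c(N)cc3nc4ccccc4nc3c2C12C(=O)N(Cc1cnnn1-c1ccc([N+](=O)[O-])cc1[N+](=O)[O-])c1ccccc12` takes this further: 2,4-dinitrophenyl in place of 5-chloro-2-methylphenyl on an aromatic nitrogen. Within the data shown here, no measured step covers a nitro group, so the expectation rests on the modest size of the aryl swaps seen so far, and compound 4 is expected near 22000 nM, within 7000 nM to 60000 nM, which would mean a step of a 1.3-fold higher number from compound 3 to compound 4 (0.10 log units; within the scatter).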

Compound 4, half-maximal inhibitory concentration: 18400 nM
The estimate for compound 4 lay 1.2-fold (0.08 log units) above the measured number, and the stated range covers the measured number.
By their numbers in this assay, from the lowest: compounds 3 and 4 (each within the scatter of the next); then compound 2. At a limit, above all of these: compound 1.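

With a 1.1-fold higher number from compound 3 to compound 4 (0.03 log units; within the scatter) in this assay, 2,4-dinitrophenyl on this aromatic nitrogen matches 5-chloro-2-methylphenyl within the scatter, although the two groups share only the six-membered aromatic ring. The dinitrophenyl group also gives a 2.5-fold lower number from compound 2 to compound 4 (0.39 log units; beyond the scatter) and an at least 2.7-fold lower number from compound 1 to compound 4 (0.43 log units; beyond the scatter), so a number beyond the scatter of compound 2 is no longer tied to the chloro group alone. Compound 1 remains a limit, so its step is only a floor: the limit of > 50000 nM in this assay, at which 1 of the 4 values shown sits.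

From the compounds shown here alone, an amine or a carboxylic acid on this aryl ring remains open. So does whether any group here reaches numbers well under those of compound 3 and compound 4.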